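The source may report more compounds than this note shows. Statements on the series, on what has been measured and on what is new or still open speak of the compounds shown alone.

Compound 1 `Cc1ccc(=O)n(CCCCCC(=N)S)n1` is read in a functional assay on the whole organism (stomach) with Rattus norvegicus as the target; on this read-out lower numbers stand for an effect already at smaller amounts and higher numbers for an effect only at larger amounts of compound. In this assay compound 1 reaches only the limit > 100 mg/kg. Compound 2 `Cc1ccc(=O)n(CCCCCCC(=N)S)n1` likewise reaches only the limit > 100 mg/kg. Compound 3 `N=C(S)CCCCCn1nc(-c2ccccc2)ccc1=O` gives 23.3 mg/kg. Two steps are measured from compound 1: the chain extension a step that the two limits leave unreadable from compound 1 to compound 2 and the aryl exchange an at least 4.2-fold lower number from compound 1 to compound 3 (0.63 log units; beyond the scatter). Compound 4 `Cc1ccc(=O)n(CCCC(=N)S)n1` differs from compound 1 in another way: a group of 3 heavy atoms (1 carbon, 1 nitrogen, 1 sulfur; no ring) in place of a group of 5 heavy atoms (3 carbon, 1 nitrogen, 1 sulfur; no ring), on a saturated chain carbon, three bonds along the chain from an aromatic nitrogen. Among the measured compounds shown here, no measured step shortens the chain, and the two values sitting at the limit of > 100 mg/kg in this assay, at which 2 of the 3 values shown sit, give no reading on chain length; the phenyl step concerns a different position and does not carry over. In this assay no step beyond the scatter is therefore expected, and compound 1 itself stands only at a limit. Compound 4 is expected near 150 mg/kg (range 40 mg/kg to 600 mg/kg), the step that the limit leaves unreadable from compound 1 to compound 4 being an estimate that stays within the limit.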

Compound 4, dose for half-maximal effect: > 100 mg/kg
Compound 4: only a limit was reported (the forecaster's own chance of this, stated with the estimate: 70%); the middle value is on the limit's open side.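

Among the compounds shown here, compound 1 and compound 4 both stand only at a limit in this assay, and no step between them can be read. The compounds shown leave open whether chain length changes the effect at all, with one value recurring: the limit of > 100 mg/kg in this assay, at which 3 of the 4 values shown sit.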